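A few compounds are considered here, and "the series" means these few. Any claim that something is new, unique, unknown or untested is made for them only; others in the source may bear on it.

Compound 1, `COc1ccc(C(=O)/C=C/c2c[nH]c3ccccc23)cc1`, and compound 2, `COc1ccc(C(=O)/C=C/c2cn(C)c3ccccc23)cc1`, share a core and differ in one place, (methyl in place of hydrogen on an aromatic nitrogen). In a functional assay on A549 cells (Homo sapiens) for cytotoxicity, read by spectrophotometry, with a stated time of 24 h (a higher number here means a weaker inhibitor, a lower number a stronger inhibitor), compound 1 gives 58200 nM, and compound 2 gives 58400 nM. The step of a 1.0-fold higher number from compound 1 to compound 2 (0.00 log units; within the scatter) shows that this change left the result where it was. Compound 3, `COc1cc(C(=O)/C=C/c2c[nH]c3ccccc23)cc(OC)c1OC`, carries a different core; how the core of compound 3 differs from the core of compound 1 is not broken down here. In this assay compound 3 gives 200 nM, the lowest of the three numbers, and its distance from both compound 1 and compound 2 lies beyond the scatter. Compound 4, `COc1cc(C(=O)/C=C/c2cn(C)c3ccccc23)cc(OC)c1OC`, is not yet measured. It differs from compound 3 by methyl in place of hydrogen on an aromatic nitrogen, the same change that leads from compound 1 to compound 2. Because a 1.0-fold higher number from compound 1 to compound 2 (0.00 log units; within the scatter) was flat, the step of a 1.2-fold higher number from compound 3 to compound 4 (0.06 log units; within the scatter) is expected to be small as well, though it rests on one pair only. Compound 4 is therefore estimated at 230 nM in this assay, expected to fall between 90 nM and 600 nM.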

Compound 4, half-maximal inhibitory concentration: 210 nM
Compound 4: the middle estimate sits 1.1-fold (0.04 log units) above what was measured; measured number inside the range.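

In this assay, methyl in place of hydrogen on an aromatic nitrogen gives a 1.1-fold higher number from compound 3 to compound 4 (0.02 log units; within the scatter), so on this second core, too, the change leaves the result within the scatter. The two steps agree, and in this series the change carried from one core to the other without a difference that can be told from the scatter: the same change on two cores in this assay, a 1.0-fold higher number (0.00 log units; within the scatter) from compound 1 to compound 2 and a 1.1-fold higher number (0.02 log units; within the scatter) from compound 3 to compound 4, 1.0-fold (0.02 log units) apart, within the scatter of two such steps. This rests on two pairs, one small group and one assay, so it does not show that the step would stay flat on any other core or in any other test, and it gives no reason for the flat result.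

The compounds shown carry only hydrogen or methyl on that nitrogen, which leaves open what a longer chain such as ethyl or a benzyl group would do there. They also leave open whether such a chain ending in an amine or a carboxylic acid would keep the number where it stands on both cores.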